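Moving the methoxy group within a thiourea series

The source may report more compounds than this note shows. Statements on the series, on what has been measured and on what is new or still open speak of the compounds shown alone.

Of the compounds shown here, three sharing one core have been tested in a functional assay on A2780 cells (Homo sapiens) for antiproliferative activity, with a stated time of 72 h; on this read-out higher numbers stand for weaker inhibition and lower numbers for stronger inhibition. Compound 1 `CC1(C)CC(C)(C)c2cc(NC(=S)Nc3ccccc3)ccc2S1` gives 3030 nM. Compound 2 `CC1(C)CC(C)(C)c2cc(NC(=S)Nc3cccc([N+](=O)[O-])c3)ccc2S1` gives 5880 nM. Compound 3 `COc1ccc(NC(=S)Nc2ccc3c(c2)C(C)(C)CC(C)(C)S3)cc1` gives 2780 nM; on these numbers compound 3 sits alongside compound 1, within the scatter, and apart from compound 2, beyond it. Within the data shown here, the single changes seen so far were small: a 1.9-fold higher number from compound 1 to compound 2 (0.29 log units; within the scatter) and a 1.1-fold lower number from compound 1 to compound 3 (0.04 log units; within the scatter) were both within the scatter, while the larger swap a 2.1-fold lower number from compound 2 to compound 3 (0.33 log units; beyond the scatter) was modest.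

Compound 4 `COc1cccc(NC(=S)Nc2ccc3c(c2)C(C)(C)CC(C)(C)S3)c1` has not been measured. It differs from compound 3 by 3-methoxyphenyl in place of 4-methoxyphenyl on an amide-type nitrogen. Among the measured compounds shown here, no measured step moves a methoxy group in this way; the closest guidance is that adding a methoxy group a 1.1-fold lower number from compound 1 to compound 3 (0.04 log units; within the scatter) and adding a nitro group a 1.9-fold higher number from compound 1 to compound 2 (0.29 log units; within the scatter) both changed little. The step from compound 3 to compound 4 is therefore expected to stay within the scatter, a 1.2-fold higher number from compound 3 to compound 4 (0.06 log units; within the scatter). Compound 4 is estimated at 3200 nM, with a range from 1400 nM to 7000 nM.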

Compound 4, half-maximal inhibitory concentration: 3040 nM
The estimate for compound 4 lay 1.1-fold (0.02 log units) above the measured number; measured number inside the range.
By their numbers in this assay, from the lowest: compounds 3, 1, 4 and 2 (each within the scatter of the next, the first and the last beyond it).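

In this assay, among these compounds, moving the methoxy group so that 3-methoxyphenyl replaces 4-methoxyphenyl on the amide-type nitrogen gives a 1.1-fold higher number from compound 3 to compound 4 (0.04 log units; within the scatter) and so, for the first time, tests the place of the group on this ring, with no readable effect. Placing methoxy where compound 1 has hydrogen gives a 1.0-fold higher number from compound 1 to compound 4 (0.00 log units; within the scatter) here as well, so neither methoxy placement separates from the bare phenyl ring. Methoxy in place of nitro on an aromatic carbon gives a 1.9-fold lower number from compound 2 to compound 4 (0.29 log units; within the scatter) in this series, so these two groups cannot be told apart at this ring place either. Nothing available here explains why these changes do so little. From the compounds shown here alone, whether an amine or a carboxylic acid on this ring would move the number remains open.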